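A few compounds are considered here, and "the series" means these few. Any claim that something is new, unique, unknown or untested is made for them only; others in the source may bear on it.

Measured so far in an assay for binding affinity to dual specificity mitogen-activated protein kinase kinase 4 (Homo sapiens), read by KINOMEscan, tested at 100 nM; a higher number here means a weaker effect of the compound at the concentration tested, a lower number a stronger effect:
- compound 1 `CCCS(=O)(=O)Nc1ccc(F)c(C(=O)c2n[nH]c3ncc(-c4cccc(Cl)c4)cc23)c1F` gives 40%
- compound 2 `CCCS(=O)(=O)Nc1ccc(F)c(C(=O)c2n[nH]c3ncc(-c4ccc(OC)cc4)cc23)c1F` gives 4.2%
- compound 3 `CCCS(=O)(=O)Nc1ccc(F)c(C(=O)c2n[nH]c3ncc(-c4cccc(O)c4)cc23)c1F` gives 2.2%

Compound 3 stands lowest of the three numbers in this assay, but compound 2 lies within the scatter of it, so the two cannot be ordered. Compound 1 stands well apart: the step of a number 37.8 percentage points lower from compound 1 to compound 3 (beyond the scatter) is large, as is the step of a number 35.8 percentage points lower from compound 1 to compound 2 (beyond the scatter). Both of the oxygen-bearing phenyls thus sit far below the 3-chlorophenyl analogue, while the exchange of one oxygen-bearing phenyl for another, a number 2 percentage points lower from compound 2 to compound 3 (within the scatter), stays within the scatter.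

Compound 4 `CCCS(=O)(=O)Nc1ccc(F)c(C(=O)c2n[nH]c3ncc(-c4ccc(O)cc4)cc23)c1F` is not yet measured. The change from compound 3 is 4-hydroxyphenyl in place of 3-hydroxyphenyl on an aromatic carbon. Within the data shown here, the only measured step that bears on it directly is a number 2 percentage points lower from compound 2 to compound 3 (within the scatter), which also moves the oxygen substituent around the phenyl ring and shows no change beyond the scatter; the large steps from compound 1 concern the loss of chloro, not the oxygen position. The step of a number 1.3 percentage points higher from compound 3 to compound 4 (within the scatter) is therefore expected to be no more than the scatter. Compound 4 is estimated at 3.5% in this assay, with a range from 1% to 12%.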

Compound 4, a percentage reported as activity, at one concentration (the size of the read-out at that concentration, not a potency): 0.75%
The estimate for compound 4 lay 2.8 percentage points above the measured number; the measured number lies below the stated range.
By their numbers in this assay, from the lowest: compounds 4, 3 and 2 (each within the scatter of the next); then compound 1.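

Working notes on the phenyl at this position: in this assay, shifting the hydroxy around the phenyl ring, a number 1.5 percentage points lower from compound 3 to compound 4 (within the scatter), does not separate 3-hydroxyphenyl from 4-hydroxyphenyl. The direct pair at the 4-position, a number 3.5 percentage points lower from compound 2 to compound 4 (within the scatter), also leaves capping of the oxygen with methyl unresolved by this read-out, so compounds 2, 3 and 4 form one group in which neither the oxygen position nor the methyl can be distinguished. With a number 39.3 percentage points lower from compound 1 to compound 4 (beyond the scatter), the 4-hydroxyphenyl joins the other two oxygen-bearing phenyls well apart from the 3-chlorophenyl of compound 1, though nothing available gives a reason for this gap.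

Still open, on these data alone, is whether the gap follows the chloro itself or its position on the ring, which a 4-chlorophenyl would address, and whether an aminophenyl or a phenyl bearing a carboxylic acid would fall with compound 1 or with the group. A read-out at a single concentration also leaves open whether compounds 2, 3 and 4 would show a stronger or weaker effect at any other concentration.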